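A few compounds are considered here, and "the series" means these few. Any claim that something is new, unique, unknown or untested is made for them only; others in the source may bear on it.

Among the measured compounds shown here, compound 2 `O=[N+]([O-])c1ccc(CSc2nc(Cl)nc3c2ncn3[C@@H]2O[C@H](CO)[C@@H](O)[C@H]2O)cc1` has the lowest number of the two measured so far in an assay on K562 cells for displacement of a labelled ligand from Equilibrative nucleoside transporter 1 (Homo sapiens), read by flow cytometry, with a stated time of 45 min (a higher number here means a weaker inhibitor, a lower number a stronger inhibitor), where compound 2 gives 11 nM. Its nearest neighbour is compound 1 `O=[N+]([O-])c1ccc(CSc2nc(NC3CCCCC3)nc3c2ncn3[C@@H]2O[C@H](CO)[C@@H](O)[C@H]2O)cc1`, which in this assay gives 400 nM; the change from compound 1 to compound 2 brought a 36-fold lower number from compound 1 to compound 2 (1.56 log units; beyond the scatter). Compound 3 `CC(=O)Nc1nc(SCc2ccc([N+](=O)[O-])cc2)c2ncn([C@@H]3O[C@H](CO)[C@@H](O)[C@H]3O)c2n1` differs from compound 2 by acetamido in place of chloro on an aromatic carbon. For the measured compounds named here, only the cyclohexylamino-to-chloro step bears on this, and it was large, so a weaker inhibitor than compound 2 is expected, though a smaller shift than the one that step showed. For compound 3 the estimated value in this assay is 80 nM (range 20 nM to 400 nM), an expected step of a 7.3-fold higher number from compound 2 to compound 3 (0.86 log units; beyond the scatter).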

Compound 3, inhibition constant: 34 nM
For compound 3 the middle estimate is 2.4-fold (0.37 log units) above the measured one; the measured number falls inside the stated range.
By their numbers in this assay, from the lowest: compound 2; then compound 3; then compound 1.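

At this position, between two ring nitrogen atoms, a group attached through nitrogen need not lose as much as cyclohexylamino: acetamido in place of chloro brings a 3.1-fold higher number from compound 2 to compound 3 (0.49 log units; beyond the scatter), a modest step. With that nitrogen kept, acetyl in place of cyclohexyl brings a 12-fold lower number from compound 1 to compound 3 (1.07 log units; beyond the scatter), so the group carried on the nitrogen strongly shifts the number. No measurement here accounts for either shift.

Open, going by these compounds, is how a free amine, a methylamino group or a longer acyl chain such as butyramido would compare with chloro and acetamido. Also open, on these data alone, is whether the same order holds with another group in place of the 4-nitrobenzyl on sulfur.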